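Chain variation on the sulfur substituent of a shared core

This account rests on a few compounds, and the source may have more. Where it says the series, first, only, none or still open, it means among the compounds named here.

Measured compounds in an in vitro functional assay on 1321-N1 cells for agonist activity at P2Y purinoceptor 6 (Homo sapiens); on this read-out higher numbers stand for an effect only at larger amounts of compound and lower numbers for an effect already at smaller amounts:
compound 1 `CSc1ccn([C@@H]2O[C@H](COP(=O)(O)OP(=O)(O)O)[C@@H](O)[C@H]2O)c(=O)n1` gives 2300 nM
compound 2 `NC(=O)CSc1ccn([C@@H]2O[C@H](COP(=O)(O)OP(=O)(O)O)[C@@H](O)[C@H]2O)c(=O)n1` gives 18000 nM
compound 3 `C=CCSc1ccn([C@@H]2O[C@H](COP(=O)(O)OP(=O)(O)O)[C@@H](O)[C@H]2O)c(=O)n1` gives 560 nM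

Compound 3 holds the lowest of the three numbers; compound 1 is its nearest neighbour and compound 2 the furthest. Both steps that reach compound 3 point downward and lie beyond the scatter: a 4.1-fold lower number from compound 1 to compound 3 (0.61 log units; beyond the scatter) and a 32-fold lower number from compound 2 to compound 3 (1.51 log units; beyond the scatter). The third measured step runs upward: a 7.8-fold higher number from compound 1 to compound 2 (0.89 log units; beyond the scatter).

Compound 4 `CCSc1ccn([C@@H]2O[C@H](COP(=O)(O)OP(=O)(O)O)[C@@H](O)[C@H]2O)c(=O)n1` differs from compound 3 by methyl in place of vinyl on a saturated chain carbon bound to a sulfur. Cut one bond further out, the change reads allyl to ethyl, so compound 4 sits between compound 1 and compound 3 on the chain attached to the sulfur. Among the measured compounds shown here, the only measured step that bears on it is a 4.1-fold lower number from compound 1 to compound 3 (0.61 log units; beyond the scatter), a modest one; the carbamoyl step from compound 1 to compound 2 concerns a different group and is not used here. Compound 4 keeps the added chain carbon of compound 3 but loses its double bond, so a partial return toward the number of compound 1 is expected, smaller than the full step from compound 1 to compound 3. Compound 4 is therefore expected to give about 1100 nM, in the range 450 nM to 2800 nM, which would mean an expected step of a 2.0-fold higher number from compound 3 to compound 4 (0.29 log units; within the scatter).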

Compound 4, half-maximal effective concentration: 280 nM
Estimate against measurement, compound 4: 3.9-fold (0.59 log units) above; measured number outside the range, below it.
By their numbers in this assay, from the lowest: compounds 4 and 3 (each within the scatter of the next); then compound 1; then compound 2.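

In this assay the change from allyl to ethyl gives a 2.0-fold lower number from compound 3 to compound 4 (0.30 log units; within the scatter) and so leaves these two sulfur substituents unresolved, which shows that the double bond outside aromatic rings is not required for a number in this range. Set against hydrogen on a saturated chain carbon bound to a sulfur, methyl gives an 8.2-fold lower number from compound 1 to compound 4 (0.91 log units; beyond the scatter) while set against carbamoyl it gives a 64-fold lower number from compound 2 to compound 4 (1.81 log units; beyond the scatter) so the drop from compound 1 seen earlier with vinyl also appears with a saturated group, and compound 2 remains the case against any reading that every added group on that carbon lowers the number. No available evidence accounts for these steps.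

The compounds shown leave open whether the number keeps falling, levels off or rises again with a longer chain such as propyl or butyl, or with a branched group such as isopropyl. They also leave open whether the rise seen with carbamoyl extends to other groups at the same place, such as a carboxylic acid, an amine or a hydroxyl.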